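The source may report more compounds than this note shows. Statements on the series, on what has been measured and on what is new or still open speak of the compounds shown alone.

Measured in a functional assay (strain AB) with Danio rerio as the target, read by microscopy, with a stated time of 1 h; a lower number here means that less compound is needed, a higher number that more compound is needed for the effect:
- compound 1 `CN1CCc2c(sc(NC(=O)Nc3ccc(Cl)cc3)c2C(N)=O)C1`: 4700 nM
- compound 2 `CC(C)(C)OC(=O)N1CCc2c(sc(NC(=O)Nc3ccc(Cl)cc3)c2C(N)=O)C1`: > 25000 nM (a limit of the assay)
- compound 3 `CC(C)(C)CN1CCc2c(sc(NC(=O)Nc3ccc(Cl)cc3)c2C(N)=O)C1`: 5560 nM

Compound 3 gives 5560 nM in this assay. The numbers show a 1.2-fold higher number from compound 1 to compound 3 (0.07 log units; within the scatter), so it stands level with the methyl compound on the shared core. Compound 2 gives > 25000 nM, which is a limit and not a number.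

Compound 4 `CC(C)(C)OC(=O)CN1CCc2c(sc(NC(=O)Nc3ccc(Cl)cc3)c2C(N)=O)C1` carries tert-butoxycarbonyl in place of tert-butyl on a saturated chain carbon bound to an amine nitrogen in a ring. Two measured steps involve the same group, placed directly on an amine nitrogen in a ring: an at least 5.3-fold higher number from compound 1 to compound 2 (0.72 log units; beyond the scatter) and an at least 4.4-fold lower number from compound 2 to compound 3 (0.65 log units; beyond the scatter). Both are beyond the scatter, and both are bounded by the limit, so their true size is not known. They point to a higher number with tert-butoxycarbonyl present. In compound 4, however, the group sits on the chain carbon, the place where a 1.2-fold higher number from compound 1 to compound 3 (0.07 log units; within the scatter) brought no change beyond the scatter. Only part of the earlier effect is therefore expected to carry over, giving a small rise in this assay that may not clear the scatter. The expected change is a 1.6-fold higher number from compound 3 to compound 4 (0.21 log units; within the scatter). For compound 4 the estimate is 9000 nM, with an expected range from 3500 nM to 25000 nM.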

Compound 4, half-maximal effective concentration: > 25000 nM
Compound 4 gave a limit, no number (the forecaster's own chance of this, stated with the estimate: 20%); middle value at least 2.7-fold (0.44 log units) away from the limit.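

In this assay, the saturated chain carbon bound to an amine nitrogen in a ring had so far shown only a change within the scatter (a 1.2-fold higher number from compound 1 to compound 3 (0.07 log units; within the scatter)), and the new result shows that this place is not indifferent to what it carries (an at least 4.4-fold higher number from compound 3 to compound 4 (0.65 log units; beyond the scatter)). The value of compound 4 is a limit of the assay and not a number, yet it still clears the scatter against the methyl compound (an at least 5.3-fold higher number from compound 1 to compound 4 (0.72 log units; beyond the scatter)). Tert-butoxycarbonyl thus goes with a higher number both directly on the amine nitrogen, in compound 2, and on the chain carbon, in compound 4, but the step between these two compounds cannot be read, because both sit at the same limit: the limit of > 25000 nM in this assay, at which 2 of the 4 values shown sit.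

On these data alone, how far the true values of compound 2 and compound 4 lie from that limit remains open, and with it the full size of the change. Also open, as far as these compounds go, is whether the rise belongs to the whole tert-butoxycarbonyl group or to its carbonyl alone, which a carboxylic acid or a simple primary amide on the same chain carbon would help to separate.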